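This account rests on a few compounds, and the source may have more. Where it says the series, first, only, none or still open, it means among the compounds named here.

Measured compounds:
Compound 1, `CCCN(CCC(F)(F)F)Cc1c(C(F)(F)F)nc2n(-c3c(C)cc(C)cc3C)c(Cl)cn12`, gives 12 nM in an assay on cells for displacement of a labelled ligand from corticotropin-releasing factor receptor 1 (Homo sapiens), with a stated time of 100 min; on this read-out higher numbers stand for weaker inhibition and lower numbers for stronger inhibition.
Compound 2, `CCCCN(CC)Cc1c(C(F)(F)F)nc2n(-c3c(C)cc(C)cc3C)c(Cl)cn12`, gives 78 nM.
Compound 3, `CCCCN(C)Cc1c(C(F)(F)F)nc2n(-c3c(C)cc(C)cc3C)c(Cl)cn12`, gives 310 nM.

Compound 3 stands highest of the three numbers. Its nearest neighbour is compound 2, with the step of a 4.0-fold higher number from compound 2 to compound 3 (0.60 log units; beyond the scatter); the furthest is compound 1, with the step of a 26-fold higher number from compound 1 to compound 3 (1.41 log units; beyond the scatter). Compound 4 is `C=CCN(CC=C)Cc1c(C(F)(F)F)nc2n(-c3c(C)cc(C)cc3C)c(Cl)cn12`. The change from compound 3 is diallylamino in place of butyl(methyl)amino on a saturated chain carbon bound to an aromatic carbon.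

Among the measured compounds shown here, two measured steps bear on this change. The step of a 4.0-fold higher number from compound 2 to compound 3 (0.60 log units; beyond the scatter) shows that a single extra carbon on the amine side raises the number when removed, and the step of a 26-fold higher number from compound 1 to compound 3 (1.41 log units; beyond the scatter) shows that two chains of three carbons each, in place of butyl and methyl, give a far lower number. Compound 4 carries two chains of three carbons on the amine nitrogen, so a modest to large drop in the number toward compounds 2 and 1 is expected. Compound 4 is therefore expected to step by a 7.8-fold lower number from compound 3 to compound 4 (0.89 log units; beyond the scatter). Compound 4 is estimated at 40 nM, in the range 10 nM to 150 nM.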

Compound 4, inhibition constant: 13 nM
Beside the measured number, compound 4's estimate is 3.1-fold (0.49 log units) above it; measured number inside the range.
By their numbers in this assay, from the lowest: compounds 1 and 4 (each within the scatter of the next); then compound 2; then compound 3.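

In this assay, diallylamino on this saturated chain carbon gives a 24-fold lower number from compound 3 to compound 4 (1.38 log units; beyond the scatter) and a 6.0-fold lower number from compound 2 to compound 4 (0.78 log units; beyond the scatter), so a low number at this place is not confined to an amine that carries the 3,3,3-trifluoropropyl chain. With a 1.1-fold higher number from compound 1 to compound 4 (0.03 log units; within the scatter), the diallylamino and propyl(3,3,3-trifluoropropyl)amino groups cannot be told apart here, although one has two double bonds and no fluorine and the other has fluorine and no double bonds. Nothing measured here accounts for these steps.

The compounds shown leave open how a saturated dipropylamino group would compare with diallylamino at this place, and so whether the double bonds matter at all. Also open, on these data alone, is whether a ring amine such as morpholine, or a longer chain as in dibutylamino, would give a number in this range.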